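This account rests on a few compounds, and the source may have more. Where it says the series, first, only, none or still open, it means among the compounds named here.

Compound 1 `N#Cc1ccc2ccc(C(=O)c3ccc(F)c(O)c3)nc2c1`: 25000 nM
Compound 2 `Oc1cc(Nc2cccc(-c3cccc(O)c3F)n2)ccc1F`: > 200000 nM

Going by the values given here, in a physicochemical assay for solubility, in phosphate buffer, with a stated time of 24 h, at pH 7.4, tested at 200 uM (a lower number here means a less soluble compound, a higher number a more soluble compound), compound 1 gives 25000 nM, the only plain number among the values shown. For compound 2 the value > 200000 nM is a limit of the assay and not a number. That is the limit of > 200000 nM in this assay, at which 1 of the 2 values shown sits. Compound 3 `Nc1ccc2ccc(C(=O)c3ccc(F)c(O)c3)nc2c1` has not been measured yet. It differs from compound 1 by amino in place of cyano on an aromatic carbon. Among the compounds with values here, no measured step of this kind exists here, so the expectation rests on the change alone: a moderate rise in this assay, beyond the usual scatter. Compound 3 is expected to give 60000 nM, between 20000 nM and 200000 nM. The expected step of a 2.4-fold higher number from compound 1 to compound 3 (0.38 log units; beyond the scatter) is upward.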

Compound 3, solubility: > 200000 nM
Compound 3 ended at the assay's limit; the forecaster's own chance of this, stated with the estimate: 15%; middle value at least 3.3-fold (0.52 log units) from the limit.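

In this assay, going by these compounds alone, amino in place of cyano on this aromatic carbon gives an at least 8.0-fold higher number from compound 1 to compound 3 (0.90 log units; beyond the scatter), the first measured step at this position. Compound 3 gives > 200000 nM, which is a limit of the assay and not a number, so the step has a known minimum but no known size. A second compound now sits at this ceiling: the limit of > 200000 nM in this assay, at which 2 of the 3 values shown sit.

Going by these compounds, how far the true value of compound 3 lies past that limit stays open. So does whether a carboxylic acid or a methoxy group on the same aromatic carbon would also reach it.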